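The compounds below may be only part of what the source reports. "The series", "measured", "known", "first", "only" and "open" are said of these compounds alone.

Measured compounds:
compound 1, `O=C(c1cc(-c2ccc(Cl)cc2Cl)n[nH]1)N1CCOCC1`, with 574 nM in an assay on isolated protein for inhibition of alkaline phosphatase, tissue-nonspecific isozyme (Homo sapiens); on this read-out higher numbers stand for weaker inhibition and lower numbers for stronger inhibition
compound 2, `O=C(NCCO)c1cc(-c2cc(F)c(Cl)cc2Cl)n[nH]1`, with 100 nM in this assay
compound 3, `CN(C)C(=O)c1cc(-c2cc(F)c(Cl)cc2Cl)n[nH]1`, with 324 nM in this assay

Among these three, compound 1 has the highest number in this assay. Compound 3 stands nearest to it, and the two lie within the scatter of each other. Compound 2 stands furthest away, with a lower number that is beyond the scatter, so compound 2 inhibits more strongly than compound 1.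

The unmeasured compound 4, `CCN(CC)C(=O)c1cc(-c2ccc(Cl)cc2Cl)n[nH]1`, differs from compound 1 in one place: diethylamino in place of morpholin-4-yl on a carbonyl carbon. Going by the values given here, only one measured step touches the group on the carbonyl carbon, and it is taken on a different aryl part of the shared core: a 3.2-fold higher number from compound 2 to compound 3 (0.51 log units; beyond the scatter). That step exchanged a (2-hydroxyethyl)amino for a dimethylamino; the change from compound 1 to compound 4 likewise exchanges a group that carries a hydrogen-bond acceptor for a plain dialkylamino group. On this single precedent the step expected in the same direction is a 1.6-fold higher number from compound 1 to compound 4 (0.20 log units; within the scatter). Compound 4 is therefore estimated at 900 nM in this assay, with a range from 350 nM to 2500 nM.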

Compound 4, half-maximal inhibitory concentration: 285 nM
Beside the measured number, compound 4's estimate is 3.2-fold (0.50 log units) above it; the measured number lies below the stated range.
By their numbers in this assay, from the lowest: compound 2; then compounds 4, 3 and 1 (each within the scatter of the next).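

On the carbonyl carbon of the shared core, replacing morpholin-4-yl with diethylamino gives a 2.0-fold lower number from compound 1 to compound 4 (0.30 log units; within the scatter) in this assay, so on this core neither the ring nor the hydrogen-bond acceptor of morpholin-4-yl proves necessary for inhibition within the resolution of this assay. Going by these compounds alone, the only earlier step at this place, a 3.2-fold higher number from compound 2 to compound 3 (0.51 log units; beyond the scatter), lay beyond the scatter and was taken on a different aryl part, whereas this exchange of one tertiary amide group for another stays within the scatter and does not carry that earlier loss over to this core. No measurement of any property of these groups bears on the result, so the data offer no account of it.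

The compounds shown leave open whether the (2-hydroxyethyl)amino group would give the same gain on the aryl part of compound 1, and whether the aryl change itself alters inhibition, since no pair differs there alone. They also leave open how piperidin-1-yl, which keeps the ring and lacks the oxygen, or a longer chain such as dipropylamino would compare with diethylamino at this carbonyl carbon.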